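The compounds below may be only part of what the source reports. "The series", "measured", "known", "first", "only" and "open" are said of these compounds alone.

In a functional assay on HCT-116 cells (Homo sapiens) for cytotoxicity, read by MTT assay, with a stated time of 72 h (a lower number here means a stronger inhibitor, a higher number a weaker inhibitor), compound 1 `CC(C)NC(=S)N/N=C1\CC(c2ccc(O)cc2)Oc2cc(O)ccc21` gives 38200 nM. Compound 2 `Oc1ccc(C2C/C(=N\NC(=S)N3CCOCC3)c3ccc(O)cc3O2)cc1` gives 63500 nM, and compound 3 `Oc1ccc(C2C/C(=N\NC(=S)N3CCCC3)c3ccc(O)cc3O2)cc1` gives 52300 nM. Compound 1 therefore stands level with the other two, since the gaps among all three lie within the scatter.

Compound 4 `CCCN(CCC)C(=S)N/N=C1\CC(c2ccc(O)cc2)Oc2cc(O)ccc21` has not yet been measured. It keeps the core of compound 1 but has dipropylamino in place of isopropylamino on a thiocarbonyl carbon.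

Two measured steps replace the same isopropylamino group. Morpholin-4-yl gives a 1.7-fold higher number from compound 1 to compound 2 (0.22 log units; within the scatter), and pyrrolidin-1-yl gives a 1.4-fold higher number from compound 1 to compound 3 (0.14 log units; within the scatter). Both steps stay within the scatter, as does a 1.2-fold lower number from compound 2 to compound 3 (0.08 log units; within the scatter). Among the measured compounds shown here, no measured compound carries dipropylamino, so these steps are only a rough guide and the range must stay wide.

On this evidence, no step beyond the scatter is expected in this assay. The estimated change is a 1.2-fold higher number from compound 1 to compound 4 (0.09 log units; within the scatter). Compound 4 is expected to give about 47000 nM, with an estimated range of 22000 nM to 95000 nM.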

Compound 4, half-maximal inhibitory concentration: 41900 nM
Estimate against measurement, compound 4: 1.1-fold (0.05 log units) above; measured number inside the range.
By their numbers in this assay, from the lowest: compounds 1, 4, 3 and 2 (each within the scatter of the next).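

In this assay, the place on the thiocarbonyl carbon also accepts dipropylamino, a larger group with no ring and no hydrogen-bond donor, in place of isopropylamino, giving a 1.1-fold higher number from compound 1 to compound 4 (0.04 log units; within the scatter). The same holds against the two ring-bearing groups, with dipropylamino in place of pyrrolidin-1-yl giving a 1.2-fold lower number from compound 3 to compound 4 (0.10 log units; within the scatter), and in place of morpholin-4-yl giving a 1.5-fold lower number from compound 2 to compound 4 (0.18 log units; within the scatter). Nothing measured here accounts for how close these numbers stay.

The compounds shown leave open whether a different kind of group on this carbon, such as a plain unsubstituted amino group or a chain ending in a carboxylic acid, would produce a step beyond the scatter. All four compounds share the same core, so they also leave open what replacing its hydroxyl groups with methoxy groups would do.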